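The compounds below may be only part of what the source reports. "The series", "measured", "known", "first", "only" and "open" are said of these compounds alone.

Measured compounds:
Compound 1 `O=C1C=CC(O)(c2cc3ccc(F)cc3n2S(=O)(=O)c2ccccc2)C=C1` gives 16 nM in a functional assay on cells (Panel NCI-60 (60 carcinoma cell lines), Homo sapiens); a lower number here means a stronger inhibitor of growth, a higher number a weaker inhibitor of growth.
Compound 2 `CC(C)c1cc(C(C)C)c(S(=O)(=O)n2c(C3(O)C=CC(=O)C=C3)cc3ccccc32)c(C(C)C)c1` gives 430 nM in this assay.
Compound 3 `O=C1C=CC(O)(c2cc3ccccc3n2S(=O)(=O)c2ccc3ccccc3c2)C=C1` gives 190 nM in this assay.

Among these three numbers compound 3 stands second highest in this assay. Its nearest neighbour is compound 2, whose number lies higher by a margin beyond the scatter; compound 1 sits far lower, again beyond the scatter. The unmeasured compound 4 `O=C1C=CC(O)(c2cc3ccccc3n2S(=O)(=O)c2ccccc2)C=C1` differs from compound 3 in one place: phenyl in place of naphthalen-2-yl on a sulfonyl sulfur. Going by the values given here, no pair of measured compounds isolates this change, so the expectation rests on the wider picture: compound 1, which also carries phenyl on the sulfonyl sulfur, gives 16 nM and holds the lowest number, while compounds 2 and 3 with other groups there sit higher. Compound 4 is therefore expected to move downward, a step of a 3.8-fold lower number from compound 3 to compound 4 (0.58 log units; beyond the scatter) that should reach beyond the scatter. Compound 4 is estimated at 50 nM, with a range from 15 nM to 160 nM.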

Compound 4, concentration for 50% growth inhibition: 39 nM
For compound 4 the middle estimate is 1.3-fold (0.11 log units) above the measured one; low and high end bracket the measured number.
By their numbers in this assay, from the lowest: compound 1; then compound 4; then compound 3; then compound 2.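

In this assay, going by these compounds alone, phenyl in place of naphthalen-2-yl on a sulfonyl sulfur gives a 4.9-fold lower number from compound 3 to compound 4 (0.69 log units; beyond the scatter), the first direct reading at this position, and it favours the group with one aromatic ring over the one with two. Elsewhere on the shared core, hydrogen in place of fluoro on an aromatic carbon gives a 2.4-fold higher number from compound 1 to compound 4 (0.39 log units; beyond the scatter), so the low number of compound 1 does not rest on phenyl alone. Nothing at hand accounts for either step.

The compounds shown leave open how a methyl group or a pyridine ring on the sulfonyl sulfur would compare with phenyl. They also leave open whether fluoro would lower the number again alongside naphthalen-2-yl, and how chloro or methoxy would compare with fluoro on that aromatic carbon.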